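Removing One Methoxy Group from Compound 1

The compounds below may be only part of what the source reports. "The series", "measured", "known", "first", "only" and "open" are said of these compounds alone.

- Compound 1 `COc1ccc(-c2cccc(=O)n2-c2cc(OC)c(OC)c(OC)c2)cc1O`: < 10 nM (a limit)
- Compound 2 `COc1cc(-n2c(-c3ccc([N+](=O)[O-])cc3)cccc2=O)cc(OC)c1OC`: 201 nM
- Compound 3 `COc1cc(-c2cccc(=O)n2-c2cc(OC)c(OC)c(OC)c2)cc(OC)c1OC`: 844 nM

In a functional assay on SK-OV-3 cells (Homo sapiens) for cytotoxicity, read by spectrophotometry, with a stated time of 72 h (a lower number here means a stronger inhibitor, a higher number a weaker inhibitor), compound 1 stands at < 10 nM, which is a limit of the assay and not a number. Compound 4 `COc1cc(-n2c(-c3cccc(O)c3)cccc2=O)cc(OC)c1OC` keeps the core of compound 1 but has hydrogen in place of methoxy on an aromatic carbon, ortho to a hydroxy group: hydrogen in place of methoxy on an aromatic carbon. For the measured compounds named here, the only measured step that replaces this 3-hydroxy-4-methoxyphenyl group is large: an at least 20-fold higher number from compound 1 to compound 2 (1.30 log units; beyond the scatter). Compound 3, at 844 nM, also lacks that group. The change in compound 4 is smaller, keeping the hydroxy group, yet a clear weakening beyond the scatter is still expected: an at least 15-fold higher number from compound 1 to compound 4 (1.17 log units; beyond the scatter). Compound 4 is estimated at 150 nM, with an expected range of 30 nM to 700 nM.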

Compound 4, half-maximal inhibitory concentration: 1460 nM
Estimate against measurement, compound 4: 9.7-fold (0.99 log units) below; the whole stated range lies below it.
By their numbers in this assay, from the lowest: compound 2; then compounds 3 and 4 (each within the scatter of the next). At a limit, below all of these: compound 1.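

With the hydroxy group kept, removing only the methoxy group is enough for a large loss in this assay, with an at least 140-fold higher number from compound 1 to compound 4 (2.16 log units; beyond the scatter). The methoxy group of the 3-hydroxy-4-methoxyphenyl group therefore matters in this series, and the hydroxy group alone does not hold the activity. The 3-hydroxyphenyl group also compares poorly with 4-nitrophenyl, with a 7.3-fold higher number from compound 2 to compound 4 (0.86 log units; beyond the scatter).

On these data alone, whether an ethoxy group or an amine at this place would hold the activity remains open. The full size of the loss also remains open, since compound 1 gives only a limit: the limit of < 10 nM in this assay, at which 1 of the 4 values shown sits.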